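A Benzyl for a Butoxy on the Urea Aryl Ring

The compounds below may be only part of what the source reports. "The series", "measured", "known", "first", "only" and "open" are said of these compounds alone.

Compound 2 `CCCCOc1ccc(NC(=O)n2nc(N)c3ccccc32)cc1` carries a butoxy group on its aryl ring, and in a functional assay on SF-268 cells (Homo sapiens) for inhibition, read by sulforhodamine B assay, with a stated time of 48 h (a lower number here means a stronger inhibitor of growth, a higher number a weaker inhibitor of growth), compound 2 gives 25800 nM. That is the lowest of the two numbers recorded, though the gap to its neighbour lies within the scatter: compound 3 `Nc1nn(C(=O)Nc2c(F)cccc2F)c2ccccc12` gives 36200 nM in this assay. Compound 1 `COc1ccc(NC(=O)Nc2n[nH]c3ccccc23)cc1` reaches only a limit, and in this assay compound 1 gives > 100000 nM. That limit is the limit of > 100000 nM in this assay, at which 1 of the 3 values shown sits.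

Compound 4 `Nc1nn(C(=O)Nc2ccc(Cc3ccccc3)cc2)c2ccccc12` has not yet been measured in this assay. It differs from compound 2 in one place: benzyl in place of butoxy on an aromatic carbon. Among the measured compounds shown here, no step between two measured compounds has been recorded, so there is no measured guide for this exchange. Given that compound 2 sits at 25800 nM and compound 3 sits within the scatter of it, the expected step of a 1.3-fold lower number from compound 2 to compound 4 (0.11 log units; within the scatter) is small and not clearly beyond the scatter in either direction. Compound 4 is accordingly estimated at 20000 nM, with an expected range from 6000 nM to 70000 nM.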

Compound 4, concentration for 50% growth inhibition: 4660 nM
Compound 4: the middle estimate sits 4.3-fold (0.63 log units) above what was measured, and the stated range ends above it.
By their numbers in this assay, from the lowest: compound 4; then compounds 2 and 3 (each within the scatter of the next). At a limit, above all of these: compound 1.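

In this assay, among the compounds shown here, benzyl in place of butoxy on an aromatic carbon, para to a large group, brings a 5.5-fold lower number from compound 2 to compound 4 (0.74 log units; beyond the scatter), the first step that can be read between two compounds differing in one place. It shows that the number in this assay does respond to the group at this position, and that butoxy and benzyl are not interchangeable there. No measurement shown gives a reason for this step.

The compounds shown leave open whether the step belongs to the six-membered aromatic ring that benzyl brings or to the loss of the oxygen and the open chain of butoxy. On these data alone, a phenoxy group, a cyclohexylmethyl group or a pentyl chain at the same place could separate these, and how any of them would read in this assay remains open.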